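Trading a Butyl Chain for Chlorine on the Amide

The source may hold more compounds than are shown below. What is called first, only, known or untested is meant among the compounds shown, and "the series" means these compounds.

Compound 1 `CCCCCC(=O)Nc1ccc(S(=O)(=O)Oc2ccccc2C(C)C)cc1` gives 6400 nM in a functional assay on HT-29 cells (Homo sapiens) for antiproliferative activity, read by sulforhodamine B assay, with a stated time of 48 h; on this read-out lower numbers stand for stronger inhibition and higher numbers for weaker inhibition. Compound 2 `CCCCCC(=O)Nc1ccc(S(=O)(=O)Oc2ccccc2I)cc1` gives 13000 nM in this assay, and a 2.0-fold higher number from compound 1 to compound 2 (0.31 log units; beyond the scatter). Going by the values given here, compound 2 thus carries the higher of the two numbers measured so far. Compound 3 `O=C(CCl)Nc1ccc(S(=O)(=O)Oc2ccccc2I)cc1` differs from compound 2 only on the amide side: chloro in place of butyl on a saturated chain carbon bound to a carbonyl carbon. Among the compounds with values here, the single measured step concerns the other ring, so no observed step bears directly on this change. Compound 3 is expected to land near the previous number, giving a 1.3-fold lower number from compound 2 to compound 3 (0.11 log units; within the scatter) and an estimated 10000 nM, between 3000 nM and 40000 nM.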

Compound 3, half-maximal inhibitory concentration: 4100 nM
Compound 3: the middle estimate sits 2.4-fold (0.39 log units) above what was measured; low and high end bracket the measured number.
By their numbers in this assay, from the lowest: compounds 3 and 1 (each within the scatter of the next); then compound 2.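

Going by these compounds alone, this is the first change on the amide side, and in this assay putting chloro in place of butyl on a saturated chain carbon bound to a carbonyl carbon gives a 3.2-fold lower number from compound 2 to compound 3 (0.50 log units; beyond the scatter) as a modest gain. The long pentyl chain of the amide is therefore not needed for activity in this pair. The data offer no measured explanation for this gain.

Going by these compounds, it remains open whether losing butyl or gaining chloro matters more, and how a methyl group or an amine would compare at this carbon. On these data alone, whether the same change holds with isopropyl on the other ring also remains open.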